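A few compounds are considered here, and "the series" means these few. Any claim that something is new, unique, unknown or untested is made for them only; others in the source may bear on it.

Of the compounds shown here, three built on a shared core have been tested in a functional assay on HCT-116 cells (Homo sapiens) for inhibition, read by sulforhodamine B assay, with a stated time of 2 days; a lower number here means a stronger inhibitor of growth, a higher number a weaker inhibitor of growth. Compound 1 `CC1=C(C(=O)Nc2ccc(C)cc2)C(c2ccc(O)cc2O)NC(SCc2ccccc2)=N1` gives 14500 nM, and compound 2 `CC1=C(C(=O)Nc2ccc(C)cc2)C(c2ccc(O)cc2O)NC(NCc2ccccc2)=N1` gives 66700 nM. Compound 3 `CC1=C(C(=O)Nc2cccc([N+](=O)[O-])c2)C(c2ccc(O)cc2O)NC(Nc2ccc(S(=O)(=O)Nc3ncccn3)cc2)=N1` gives 77600 nM, which lies within the usual scatter of repeat measurements of the value for compound 2 and is clearly higher than the value for compound 1.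

Compound 4 `CC1=C(C(=O)Nc2cccc([N+](=O)[O-])c2)C(c2ccc(O)cc2O)NC(Nc2ccc(S(=O)(=O)Nc3nc(C)cc(C)n3)cc2)=N1` differs from compound 3 in one place: 4,6-dimethylpyrimidin-2-yl in place of pyrimidin-2-yl on a sulfonamide nitrogen. In words, 4,6-dimethylpyrimidin-2-yl stands in place of pyrimidin-2-yl on a sulfonamide nitrogen.

Among the compounds with values here, only one measured step exists between compounds that differ in a single place, and it concerns another part of the molecule. Benzylamino in place of benzylsulfanyl gives a 4.6-fold higher number from compound 1 to compound 2 (0.66 log units; beyond the scatter). That step shows that one small change on this core can move the number, but it says nothing about this sulfonamide substituent, in size or in direction. The best guide is therefore compound 3 itself, at 77600 nM, and no shift beyond the scatter is expected in this assay. The expected step is a 1.1-fold lower number from compound 3 to compound 4 (0.04 log units; within the scatter). For compound 4 the estimated value is 70000 nM, with an expected range from 30000 nM to 150000 nM.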

Compound 4, concentration for 50% growth inhibition: 8990 nM
Compound 4: middle estimate off by 7.8-fold (0.89 log units), on the high side; the measured number lies below the stated range.
By their numbers in this assay, from the lowest: compounds 4 and 1 (each within the scatter of the next); then compounds 2 and 3 (each within the scatter of the next).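

In this assay, an 8.6-fold lower number from compound 3 to compound 4 (0.94 log units; beyond the scatter) follows from placing 4,6-dimethylpyrimidin-2-yl in place of pyrimidin-2-yl on the sulfonamide nitrogen, so this outer part of the molecule clearly affects the read-out. Within the data shown here, until now, the only readable single change was the swap from benzylsulfanyl to benzylamino, which raised the number; this result shows a second place on the shared core where one change matters, and here the larger group gives the lower number, meaning stronger growth inhibition. Nothing shown explains why the two added methyl groups have this effect.

The compounds shown leave open whether both methyl groups are needed, as a pyrimidine with a single methyl group would test, and whether larger groups such as ethyl or methoxy at the same ring positions would lower the number further or raise it. Among these compounds, this change is also seen only in one setting, so it remains unknown whether the same swap would give a similar step with another group on the amide nitrogen of the core.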